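This account rests on a few compounds, and the source may have more. Where it says the series, first, only, none or still open, it means among the compounds named here.

In an ADME assay on Caco-2 cells (Homo sapiens) for permeability, in the apical to basolateral direction (on this read-out lower numbers stand for lower permeability and higher numbers for higher permeability), compound 1 `CC(=O)N1CCN([C@H]2CC[C@H](Nc3ncnn4ccc(C5CCOCC5)c34)CC2)CC1` gives 30 10^-6 cm/s, and compound 2 `CN(C)[C@H]1CC[C@H](Nc2ncnn3ccc(C4CCOCC4)c23)CC1` gives 14 10^-6 cm/s, the lower of the two numbers. The change to compound 3 `CN(C)[C@H]1CC[C@H](Nc2ncnn3ccc([C@H]4CC[C@H](C(N)=O)CC4)c23)CC1` is 4-carbamoylcyclohexyl in place of oxan-4-yl on an aromatic carbon. Going by the values given here, the only measured step, a 2.1-fold lower number from compound 1 to compound 2 (0.33 log units; beyond the scatter), is modest and lies at a different place, so it gives only a rough scale and does not test this change. A fall larger than that modest step is expected in this assay, as a judgement from the structural change alone. The estimated change is a 2.8-fold lower number from compound 2 to compound 3 (0.45 log units; beyond the scatter). For compound 3 the estimate is 5 10^-6 cm/s, with an expected range of 1.5 10^-6 cm/s to 13 10^-6 cm/s.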

Compound 3, apparent permeability: < 0.8 10^-6 cm/s
Compound 3 was reported as a limit; the forecaster's own chance of this, stated with the estimate: 5%; middle value at least 6.2-fold (0.79 log units) away from the limit.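

The position on the aromatic carbon of the five-membered ring is sensitive in this assay, which the earlier pair, differing only on a saturated ring carbon, could not show: an at least 17-fold lower number from compound 2 to compound 3 (1.24 log units; beyond the scatter). This is a large step, set against the modest 2.1-fold lower number from compound 1 to compound 2 (0.33 log units; beyond the scatter). Compound 3 stands as a limit, so its step gives only a minimum size: the limit of < 0.8 10^-6 cm/s in this assay, at which 1 of the 3 values shown sits.

The compounds shown do not separate the carbamoyl group from the carbon ring that carries it, so the share of each in the fall remains open. A plain cyclohexyl or a 4-cyanocyclohexyl at this position would split the two.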